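The source may report more compounds than this note shows. Statements on the series, on what has been measured and on what is new or still open speak of the compounds shown alone.

In an ADME assay on BJ cells (Homo sapiens), read by MTT assay, with a stated time of 72 h (on this read-out lower numbers stand for stronger inhibition and higher numbers for weaker inhibition), compound 3 (`Cc1nc(N)c2c(-c3ccco3)cn([C@@H]3O[C@H](CO)[C@@H](O)[C@H]3O)c2n1`) gives > 100000 nM, which is a limit and not a number. Compound 2 (`Nc1nc(N)c2c(-c3ccco3)cn([C@@H]3O[C@H](CO)[C@@H](O)[C@H]3O)c2n1`) gives > 100000 nM, likewise a limit. Compound 1 (`CNc1ncnc2c1c(-c1ccco1)cn2[C@@H]1O[C@H](CO)[C@@H](O)[C@H]1O`) gives a true number, 5040 nM. The series therefore stands largely on (the limit of > 100000 nM in this assay, at which 2 of the 3 values shown sit), and compound 3 offers only a floor to start from.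

Compound 4 (`C#Cc1cn([C@@H]2O[C@H](CO)[C@@H](O)[C@H]2O)c2nc(C)nc(N)c12`) carries ethynyl in place of furan-2-yl on an aromatic carbon of the five-membered aromatic ring: ethynyl in place of furan-2-yl on an aromatic carbon. Going by the values given here, the one measured step is a step that the two limits leave unreadable from compound 2 to compound 3. That step concerns methyl in place of amino, not the furan-2-yl group, so it gives no size to carry over. Among the compounds with values here, no measured step covers this exchange, and the expectation is correspondingly loose.

Starting from a limit, any readable value for compound 4 would lie on the side of lower numbers in this assay, meaning stronger inhibition, and a second limit remains quite possible. Compound 1 at 5040 nM shows that a number can be reached in this series. The expected size is an at least 4.0-fold lower number from compound 3 to compound 4 (0.60 log units; beyond the scatter), though it is only loosely estimated. For compound 4 the estimated value is 25000 nM, with an expected range from 2000 nM to 100000 nM.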

Compound 4, half-maximal inhibitory concentration: > 100000 nM
Compound 4 ended at the assay's limit; the forecaster's own chance of this, stated with the estimate: 40%; at least 4.0-fold (0.60 log units) between middle value and limit.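

In this assay, compound 3 and compound 4 each give only a limit and not a number, so ethynyl in place of furan-2-yl yields no readable step between them. Still open, going by these compounds, is whether this exchange would shift the read-out on a compound with a true number, such as compound 1 at 5040 nM.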